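Cyclohexyl ether series: trimethyl to dimethyl ring on MDBK cells

The source may report more compounds than this note shows. Statements on the series, on what has been measured and on what is new or still open speak of the compounds shown alone.

Notes on the step from compound 1 to compound 4 in an ADME assay on MDBK cells (Bos taurus) for cytotoxicity, read by MTT assay; on this read-out higher numbers stand for lower toxicity in this test and lower numbers for higher toxicity in this test.

Compound 1 `CC1CC(OCCCCCCN2C[C@H](O)[C@@H](O)[C@H](O)[C@H]2CO)CC(C)(C)C1` gives 250000 nM in this assay. Compound 3 `CCCCC1CCC(OCCCCCCN2C[C@H](O)[C@@H](O)[C@H](O)[C@H]2CO)CC1` gives 190000 nM in this assay, a value within the usual scatter of that of compound 1, so the two cannot be told apart. Compound 2 `OC[C@@H]1[C@@H](O)[C@H](O)[C@@H](O)CN1CCCCCCOc1ccc(C(F)(F)F)cc1` gives only a limit of the assay, > 500000 nM, and no number in this assay; (the limit of > 500000 nM in this assay, at which 1 of the 3 values shown sits). Among the compounds with a number, compound 1 thus stands alongside compound 3, and no step between measured compounds that differ in one place is available.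

Compound 4 `CC1CCCC(OCCCCCCN2C[C@H](O)[C@@H](O)[C@H](O)[C@H]2CO)C1C` has not yet been measured. It differs from compound 1 in one place: a group of 8 heavy atoms (8 carbon; one six-membered non-aromatic ring of carbon only) in place of a group of 9 heavy atoms (9 carbon; one six-membered non-aromatic ring of carbon only), on an oxygen on a saturated carbon. Both rings are saturated six-membered carbon rings carrying only methyl groups, and the shared core and the chain to the oxygen are unchanged. The step from compound 1 to compound 4 is expected to stay within the scatter, in no fixed direction, no change at the digits printed from compound 1 to compound 4 (within the scatter). Compound 4 is estimated at 250000 nM in this assay, with a range from 120000 nM to 500000 nM.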

Compound 4, half-maximal cytotoxic concentration: > 500000 nM
Compound 4: only a limit was reported (the forecaster's own chance of this, stated with the estimate: 20%); middle value at least 2.0-fold (0.30 log units) from the limit.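

Replacing the 3,3,5-trimethylcyclohexyl group on this oxygen with the saturated carbon ring group of 8 heavy atoms gives, in this assay, an at least 2.0-fold higher number from compound 1 to compound 4 (0.30 log units; that floor lies within the scatter). From the compounds shown here alone, compound 4 gives only a limit of the assay, > 500000 nM, not a number, so the true size of the step stays unknown and its floor alone cannot be told from scatter. The change thus gives no sign of a lower number at this position, and a saturated ring group on this oxygen now also reaches the limit: the limit of > 500000 nM in this assay, at which 2 of the 4 values shown sit.

The step alters both the count of methyl groups and their placement on the ring, and the compounds shown do not separate the two. Going by these compounds, how an amine or a carboxylic acid on the ring, or a longer chain to the oxygen, would read in this assay also stays open.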